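Series notes: shortening the saturated chain of compound 3

The source may hold more compounds than are shown below. What is called first, only, known or untested is meant among the compounds shown, and "the series" means these compounds.

Among the compounds with values here, compound 3 `CCCCCCSc1nc2ccccc2n1CC(=O)O` sits second highest of the three numbers measured so far in an assay on HEK293 cells for displacement of a labelled ligand from prostaglandin D2 receptor 2 (Homo sapiens); a lower number here means a stronger inhibitor, a higher number a weaker inhibitor; compound 3 gives 1360 nM. Its nearest neighbour is compound 1 `O=C(O)Cn1c(SCCCCOc2ccccc2)nc2ccccc21`, which in this assay gives 1400 nM, so that a 1.0-fold lower number from compound 1 to compound 3 (0.01 log units; within the scatter). The furthest is compound 2 `O=C(O)Cn1c(SCCCc2ccccc2)nc2ccccc21`, which in this assay gives 475 nM, with a 2.9-fold higher number from compound 2 to compound 3 (0.46 log units; beyond the scatter).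

Compound 4 `CCCCCSc1nc2ccccc2n1CC(=O)O` is the next member: hydrogen in place of methyl on a saturated chain carbon, five bonds along the chain from a sulfur. Within the data shown here, no measured step removes a single methyl from a saturated chain; the steps that come closest swap a ring or a phenoxy against alkyl, as in a 1.0-fold lower number from compound 1 to compound 3 (0.01 log units; within the scatter) (within the scatter) and a 2.9-fold higher number from compound 2 to compound 3 (0.46 log units; beyond the scatter) (modest). Both concern what sits at the end of the chain rather than its length, and neither shows a large swing, so a small step is expected here, if any, and a slight drift to a higher number is judged marginally more likely than a lower one.

For compound 4 in this assay the estimate is 1700 nM, expected to lie between 800 nM and 3600 nM. The expected step is a 1.3-fold higher number from compound 3 to compound 4 (0.10 log units; within the scatter).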

Compound 4, half-maximal inhibitory concentration: 1240 nM
The estimate for compound 4 lay 1.4-fold (0.14 log units) above the measured number; low and high end bracket the measured number.
By their numbers in this assay, from the lowest: compound 2; then compounds 4, 3 and 1 (each within the scatter of the next).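

Within this assay, hydrogen in place of methyl on a saturated chain carbon, five bonds along the chain from a sulfur, gives the first step in the series that changes chain length alone (a 1.1-fold lower number from compound 3 to compound 4 (0.04 log units; within the scatter)), so this shortening leaves the number unchanged within the scatter. The step to the shorter alkyl chain keeps the gap to the phenyl-ended chain of compound 2 (a 2.6-fold higher number from compound 2 to compound 4 (0.42 log units; beyond the scatter)), while methyl in place of phenoxy, four bonds along the chain from a sulfur, stays within the scatter (a 1.1-fold lower number from compound 1 to compound 4 (0.05 log units; within the scatter)). No supporting evidence is available to explain these numbers.

As far as these compounds go, whether much shorter or longer chains would keep the number remains open. So does the effect of an amine or a hydroxyl group at the chain end.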